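The compounds below may be only part of what the source reports. "The series", "measured", "known", "first", "only" and "open" are said of these compounds alone.

Two compounds share one core and differ only in how one carbon is drawn. Compound 1 `Cc1cc(C)c(CN2CCc3c(Cl)cc([C@H](CO)[C@@H]4CCCO4)c(Cl)c3C2=O)c(=O)[nH]1` and compound 2 `Cc1cc(C)c(CN2CCc3c(Cl)cc([C@@H](CO)[C@@H]4CCCO4)c(Cl)c3C2=O)c(=O)[nH]1` were both run in an ADME assay on microsomes from liver (Homo sapiens) for metabolic stability, read by LC-MS, using NADPH, with stated times of 10 min and 45 min, tested at 1 uM (a lower number here means slower removal, a higher number faster removal of the compound), where compound 1 gives 37.6 uL/min and compound 2 gives 70.3 uL/min. Compound 2 is one of just two measured compounds, and the step of a 1.9-fold higher number from compound 1 to compound 2 (0.27 log units; within the scatter) leaves the pair within the scatter of each other, so neither stands apart. That step rests on the fact that compounds 1 and 2 differ only in the configuration as drawn and offers no guide to swapping one group for another.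

Compound 3 `Cc1cc(C)c(CN2CCc3c(Cl)cc([C@@H](C)CO)c(Cl)c3C2=O)c(=O)[nH]1` is not yet measured and differs from compound 2 in a substituent: a group of 4 heavy atoms (3 carbon, 1 oxygen; no ring) in place of a group of 8 heavy atoms (6 carbon, 2 oxygen; one five-membered non-aromatic ring with 1 hetero atom), on an aromatic carbon. Going by the values given here, no measured step changes a group in this way, so the only anchor is the value of compound 2 and the usual scatter. The step of a 1.6-fold lower number from compound 2 to compound 3 (0.19 log units; within the scatter) is therefore expected to be modest, with the direction uncertain. Compound 3 is estimated to give 45 uL/min in this assay, within a range from 20 uL/min to 100 uL/min, pending the actual measurement.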

Compound 3, intrinsic clearance in a liver preparation (reported as CLH), per the amount of preparation that the assay uses in the liver assay: 12.4 uL/min
Estimate against measurement, compound 3: 3.6-fold (0.56 log units) above; measured number outside the range, below it.
By their numbers in the liver assay, from the lowest: compound 3; then compounds 1 and 2 (each within the scatter of the next).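

Going by these compounds alone, this is the first time a group at this position is exchanged, and in the liver assay the number moves beyond the scatter: methyl in place of oxolan-2-yl gives a 3.0-fold lower number from compound 1 to compound 3 (0.48 log units; beyond the scatter), and the same exchange, seen as a change of the whole substituent, gives a 5.7-fold lower number from compound 2 to compound 3 (0.75 log units; beyond the scatter). Compound 1 and compound 2 both carry the oxolan-2-yl ring and both stand above compound 3, so exchanging the group moves the number beyond the scatter whichever way the chain carbon of the ring-bearing compound is drawn, which the change of drawn configuration alone did not do. The exchange also shows up on a second read-out: in a physicochemical assay for solubility, measured as kinetic solubility (on this read-out higher numbers stand for higher solubility and lower numbers for lower solubility), compound 2 gives 550000 nM and compound 3 gives 143000 nM, which is a 3.8-fold lower number from compound 2 to compound 3 (0.59 log units; beyond the scatter).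

From the compounds shown here alone, what stays open is whether these steps follow from losing the ring as a whole or only its oxygen, since the two go together in compound 3. An ethyl or a methoxymethyl group on the same chain carbon would tell these apart, and the opposite drawn configuration of compound 3 would show whether configuration counts once the ring is gone.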